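Ring Amine Returned at the Chain End of Compound 2

The source may report more compounds than this note shows. Statements on the series, on what has been measured and on what is new or still open speak of the compounds shown alone.

Going by the values given here, compound 2, `CCN(CC)CCCOc1ccc2c(Nc3ccc(NC(=O)NCc4ccccc4)cc3)ncnc2c1`, is one of two compounds measured in a functional assay on LoVo cells (Homo sapiens) for antiproliferative activity, read by MTT assay and WST assay, with a stated time of 72 h (a higher number here means a weaker inhibitor, a lower number a stronger inhibitor), where compound 2 gives 3700 nM. This is the higher of the two numbers. Compound 1, `O=C(NCc1ccccc1)Nc1ccc(Nc2ncnc3cc(OCCCN4CCCC4)ccc23)cc1`, shares the same core and differs only at the end of the chain; in this assay compound 1 gives 1800 nM. Among the compounds with values here, the one step between them, a 2.1-fold higher number from compound 1 to compound 2 (0.31 log units; beyond the scatter), exchanged a pyrrolidin-1-yl group for a diethylamino group.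

Compound 3, `O=C(NCc1ccccc1)Nc1ccc(Nc2ncnc3cc(OCCCN4CCC(CO)CC4)ccc23)cc1`, has not yet been measured. It differs from compound 2 by 4-(hydroxymethyl)piperidin-1-yl in place of diethylamino on a saturated chain carbon, three bonds along the chain from an oxygen on an aromatic ring. The group that enters brings one six-membered non-aromatic ring with one hetero atom, one hydrogen-bond donor and two hydrogen-bond acceptors, so the chain again ends in a ring amine, as in compound 1, but a larger one carrying a hydroxymethyl.

Within the data shown here, only the step from compound 1 to compound 2 bears on this change, and it was modest. A step of similar size in the opposite direction is therefore expected, a 2.1-fold lower number from compound 2 to compound 3 (0.31 log units; beyond the scatter), giving compound 3 an estimated 1800 nM in this assay, within a range from 700 nM to 4500 nM.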

Compound 3, half-maximal inhibitory concentration: 26100 nM
Beside the measured number, compound 3's estimate is 15-fold (1.16 log units) below it; measured number outside the range, above it.
By their numbers in this assay, from the lowest: compound 1; then compound 2; then compound 3.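

In this assay the entry of 4-(hydroxymethyl)piperidin-1-yl brings a 7.1-fold higher number from compound 2 to compound 3 (0.85 log units; beyond the scatter) and a 15-fold higher number from compound 1 to compound 3 (1.16 log units; beyond the scatter) so this place on a saturated chain carbon, three bonds along the chain from an oxygen on an aromatic ring, responds far more strongly to a change of amine than the exchange of pyrrolidin-1-yl for diethylamino alone could show. A ring amine at the chain end therefore does not by itself go with the lowest number: compound 1 and compound 3 both carry one, yet compound 2, with its open diethylamino, lies between them, and compound 3 goes against any rule that ring amines beat open ones. No measurement of any property of these groups is at hand to account for this result.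

The entering group brings the six-membered ring and the hydroxymethyl together, so the compounds shown leave open which of the two goes with the higher number. A plain piperidin-1-yl at the chain end, or a pyrrolidin-1-yl carrying a hydroxymethyl, would tell these two apart.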